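Exchanging Anilines on a Shared Core: Expecting Compound 4

The compounds below may be only part of what the source reports. "The series", "measured", "known", "first", "only" and "open" are said of these compounds alone.

Of the compounds shown here, three built on one shared core have been measured in a functional assay on NCI-H1299 cells (Homo sapiens) for antiproliferative activity, read by MTT assay, with a stated time of 72 h; a lower number here means a stronger inhibitor, a higher number a weaker inhibitor. Compound 1 `CCOC1=C(C(=O)c2ccccc2)C(c2ccc(Br)cc2)N(CCCn2ccnc2)C1=O` gives 28900 nM. Compound 2 `Cc1ccc(NC2=C(C(=O)c3ccccc3)C(c3ccc(Br)cc3)N(CCCn3ccnc3)C2=O)cc1` gives 25800 nM in this assay, and compound 3 `O=C(C1=C(Nc2ccc(Cl)cc2)C(=O)N(CCCn2ccnc2)C1c1ccc(Br)cc1)c1ccccc1` gives 25000 nM. Compound 3 has the lowest of the three numbers, yet its nearest neighbour, compound 2, and its furthest, compound 1, both sit within the scatter of it, so no order among the three can be claimed.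

Compound 4 `O=C(C1=C(Nc2cccc(Br)c2)C(=O)N(CCCn2ccnc2)C1c1ccc(Br)cc1)c1ccccc1` carries 3-bromophenyl in place of 4-chlorophenyl on an amine nitrogen. Within the data shown here, two measured steps bear on this change: a 1.2-fold lower number from compound 1 to compound 3 (0.06 log units; within the scatter), and, closest in kind, a 1.0-fold lower number from compound 2 to compound 3 (0.01 log units; within the scatter), each staying within the scatter. Since every exchange made so far on this part of the molecule has left the number within the scatter, the expected step of no change at the digits printed from compound 3 to compound 4 (within the scatter) is none beyond the scatter. Compound 4 is therefore estimated at 25000 nM in this assay, within a range from 11000 nM to 55000 nM.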

Compound 4, half-maximal inhibitory concentration: 11500 nM
For compound 4 the middle estimate is 2.2-fold (0.34 log units) above the measured one; the range from low to high includes it.
By their numbers in this assay, from the lowest: compound 4; then compounds 3, 2 and 1 (each within the scatter of the next).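

In this assay, among these compounds, the exchange to 3-bromophenyl on the amine nitrogen gives the first step on this part of the molecule to pass the scatter: a 2.2-fold lower number from compound 3 to compound 4 (0.34 log units; beyond the scatter). The exchange from 4-methylphenyl is of similar size, with a 2.2-fold lower number from compound 2 to compound 4 (0.35 log units; beyond the scatter), and replacing ethoxy with (3-bromophenyl)amino gives a 2.5-fold lower number from compound 1 to compound 4 (0.40 log units; beyond the scatter), whereas the two earlier amino groups stayed within the scatter of ethoxy; the group on this nitrogen can therefore shift the number, though only modestly. No measurement at hand accounts for this shift.

Two things differ between 4-chlorophenyl and 3-bromophenyl, the halogen and its place on the ring, and the compounds shown do not separate them. A 4-bromophenyl or 3-chlorophenyl group would address that question, while a benzyl group on the same nitrogen remains an open case.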